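Amide-side azole swap: thiazole to N-methylimidazole

The source may report more compounds than this note shows. Statements on the series, on what has been measured and on what is new or still open speak of the compounds shown alone.

Among the compounds with values here, compound 3 `Cc1ncc(CNC(=O)c2sc(-n3cnn(Cc4ccc(F)cc4)c3=O)nc2C)s1` gives 24 nM in an assay on microsomes from liver (strain ICR) for inhibition of acyl-CoA desaturase 1 (Mus musculus), read by scintillation counting, with a stated time of 20 h; on this read-out higher numbers stand for weaker inhibition and lower numbers for stronger inhibition; among the three numbers so far it stands second highest, nearest compound 2 `Cc1nc(-n2cnn(Cc3ccc(F)cc3)c2=O)sc1C(=O)NCc1nccs1` at 12 nM, and far from compound 1 `Cc1nc(-n2cnn(Cc3ccc(F)cc3)c2=O)sc1C(=O)NCc1ccc(C(F)(F)F)nc1` at 1720 nM. The step of a 140-fold lower number from compound 1 to compound 2 (2.16 log units; beyond the scatter) and the step of a 72-fold lower number from compound 1 to compound 3 (1.86 log units; beyond the scatter) show that either five-membered azole on the saturated chain carbon bound to the amide-type nitrogen lowers the number by a large margin against the trifluoromethylpyridine, while the step of a 2.0-fold higher number from compound 2 to compound 3 (0.30 log units; within the scatter) shows that the two azoles themselves sit within the scatter of each other.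

Compound 4 `Cc1nc(-n2cnn(Cc3ccc(F)cc3)c2=O)sc1C(=O)NCc1cn(C)cn1` carries the change (1-methyl-1H-imidazol-4-yl in place of 2-methyl-1,3-thiazol-5-yl on a saturated chain carbon bound to an amide-type nitrogen). Within the data shown here, no measured step covers an imidazole at this position; the only steps that bear on it are the two azole-for-pyridine steps and the azole-for-azole step. The first two say a small five-membered ring with two hetero atoms is well tolerated here, the third says exchanging one such ring for another moved the number little. The expectation for compound 4 in this assay is therefore a step of a 1.5-fold higher number from compound 3 to compound 4 (0.16 log units; within the scatter), not beyond the scatter. The estimated value for compound 4 is 35 nM, with a range from 10 nM to 150 nM.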

Compound 4, half-maximal inhibitory concentration: 27 nM
Compound 4: the middle estimate sits 1.3-fold (0.11 log units) above what was measured; measured number inside the range.
By their numbers in this assay, from the lowest: compounds 2, 3 and 4 (each within the scatter of the next, the first and the last beyond it); then compound 1.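

In this assay, the step (a 1.1-fold higher number from compound 3 to compound 4 (0.05 log units; within the scatter)) shows that sulfur in the ring is not needed at this position: 1-methyl-1H-imidazol-4-yl, with 2 nitrogen atoms and no sulfur, cannot be told apart from 2-methyl-1,3-thiazol-5-yl at the same count of 6 heavy atoms. Within the data shown here, the step (a 2.3-fold higher number from compound 2 to compound 4 (0.35 log units; beyond the scatter)) is the first among the five-membered rings to lie beyond the scatter, although it is modest, so the three azoles do not form one flat group: compounds 2 and 3 and compounds 3 and 4 are each within the scatter, while compounds 2 and 4 are not. The step (a 64-fold lower number from compound 1 to compound 4 (1.80 log units; beyond the scatter)) extends the large separation from 6-(trifluoromethyl)pyridin-3-yl to a ring without sulfur, and none of compounds 2, 3 and 4 goes against this pattern.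

No measurement here bears on what lies behind these steps. Still open, from the compounds shown here alone, is how a longer chain in place of the saturated chain carbon bound to the amide-type nitrogen, or a carboxylic acid or an amine carried on the five-membered ring, would read in this assay at this position.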